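Dimethoxyphenyl in place of dichlorophenyl on a shared core

The source may report more compounds than this note shows. Statements on the series, on what has been measured and on what is new or still open speak of the compounds shown alone.

Compound 1 `Nc1cc(N)c2nc(-c3ccccc3)c(Oc3ccc(Cl)c(Cl)c3)nc2c1` gives < 100000 nM in a functional assay on K562 cells (Homo sapiens) for inhibition, read by sulforhodamine B assay, with a stated time of 48 h; a higher number here means that more compound is tolerated, a lower number that less compound is tolerated; this is a limit of the assay, not a number.
Compound 2 `Nc1cc(N)c2nc(-c3ccccc3)c(NCc3ccc(Cl)c(Cl)c3)nc2c1` gives < 100000 nM in this assay; this too is a limit.

Compound 2 therefore stands only at a limit, and both values shown sit there, as the limit of < 100000 nM in this assay, at which 2 of the 2 values shown sit, records. Compound 3 `COc1ccc(CNc2nc3cc(N)cc(N)c3nc2-c2ccccc2)cc1OC` differs from compound 2 by 3,4-dimethoxyphenyl in place of 3,4-dichlorophenyl on a saturated chain carbon bound to a nitrogen on an aromatic ring. For the measured compounds named here, no measured step links the two, so in this assay no shift beyond the usual scatter is expected. Compound 3 is estimated at 30000 nM, within 5000 nM to 100000 nM. The step from compound 2 to compound 3 is expected to be a step that the limit leaves unreadable from compound 2 to compound 3.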

Compound 3, concentration lethal to 50% of the cells: < 100000 nM
Compound 3 gave a limit, no number; the forecaster's own chance of this, stated with the estimate: 60%; the middle value is on the limit's open side.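

No step can be read from compound 2 to compound 3, since both give only a limit in this assay: the limit of < 100000 nM in this assay, at which 3 of the 3 values shown sit.

The compounds shown leave open what concentration each actually requires, and whether 3,4-dimethoxyphenyl in place of 3,4-dichlorophenyl changes it at all.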